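Compound 2 to Compound 3 in a Cytotoxicity Screen

The source may hold more compounds than are shown below. What is called first, only, known or untested is meant among the compounds shown, and "the series" means these compounds.

Compound 1 `O=S(=O)(Nc1cccc(CO)c1)c1ccc(-c2ccc3[nH]ccc3c2)cc1` and compound 2 `CN(C)c1ccc(-c2ccc(S(=O)(=O)Nc3cccc(CO)c3)cc2)cc1` share a core and differ in a single place. In a functional assay on J774 cells (Mus musculus) for cytotoxicity, read by resazurin assay, with a stated time of 72 h (a lower number here means a stronger inhibitor, a higher number a weaker inhibitor), compound 1 gives > 5000 nM, which is a limit of the assay and not a number. In this assay compound 2 likewise gives > 5000 nM, again a limit rather than a measured number. The step that the two limits leave unreadable from compound 1 to compound 2 is therefore of unreadable size. Among the measured compounds shown here, compound 2 thus stands at the edge of what the assay reports, and this is the only evidence there is: the limit of > 5000 nM in this assay, at which 2 of the 2 values shown sit.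

Compound 3 `O=S(=O)(Nc1cccc(CO)c1)c1ccc(-c2ccccc2F)cc1` differs from compound 2 by 2-fluorophenyl in place of 4-(dimethylamino)phenyl on an aromatic carbon. No measured step concerns this replacement; the sole measured step, a step that the two limits leave unreadable from compound 1 to compound 2, involves a different group and is itself unreadable, so nothing shown points to a change beyond the scatter in either direction. Compound 3 is therefore expected to give 8000 nM, with a range from 2500 nM to 40000 nM, and most probably to be reported again only as a limit. The expected step that the limit leaves unreadable from compound 2 to compound 3 is estimated as none beyond the scatter.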

Compound 3, half-maximal inhibitory concentration: 1300 nM
Compound 3: the middle estimate sits 6.2-fold (0.79 log units) above what was measured; the measured number lies below the stated range.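

Replacing 4-(dimethylamino)phenyl with 2-fluorophenyl gives an at least 3.8-fold lower number from compound 2 to compound 3 (0.58 log units; beyond the scatter) in this assay, so a change at this place, on an aromatic carbon para to a large group, can bring the read-out down to a number, which the earlier pair could not show. Replacing 1H-indol-5-yl with the same 2-fluorophenyl gives an at least 3.8-fold lower number from compound 1 to compound 3 (0.58 log units; beyond the scatter), so the entering group gives a readable step against both of the earlier groups, even though the two groups that leave differ from each other. Both sizes are only lower bounds, and the true gaps could be larger, because compound 1 and compound 2 each stand at a limit of the assay and not at a number: the limit of > 5000 nM in this assay, at which 2 of the 3 values shown sit.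

On these data alone, it remains open whether the step goes with the fluorine itself or with the smaller group as a whole, a question that a plain phenyl group, or chlorine in place of the fluorine, would help to settle. As far as these compounds go, it also remains open how the read-out in this assay would respond to a primary amine or a carboxylic acid on the ring at this position.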